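Swapping an Ortho Methyl for Chloro on a Nitroimidazole

This account rests on a few compounds, and the source may have more. Where it says the series, first, only, none or still open, it means among the compounds named here.

The measured compounds and their values in a functional assay on MCF7 cells (Homo sapiens) for cytotoxicity, read by MTT assay, with a stated time of 48 h; a lower number here means a stronger inhibitor, a higher number a weaker inhibitor:
- compound 1, `Cc1ncc([N+](=O)[O-])n1CCSc1nnc(-c2ccccc2)o1`, gives 20500 nM
- compound 2, `Cc1ccccc1-c1nnc(SCCn2c([N+](=O)[O-])cnc2C)o1`, gives 15800 nM
- compound 3, `Cc1ncc([N+](=O)[O-])n1CCSc1nnc(-c2ccccc2N)o1`, gives 20100 nM

Compound 2 holds the lowest of these three numbers, but its neighbours sit close: the step of a 1.3-fold lower number from compound 1 to compound 2 (0.11 log units; within the scatter) and the step of a 1.3-fold higher number from compound 2 to compound 3 (0.10 log units; within the scatter) are both within the usual scatter, so no one of the three can be called stronger than another on this evidence. The step of a 1.0-fold lower number from compound 1 to compound 3 (0.01 log units; within the scatter) is equally flat.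

Compound 4, `Cc1ncc([N+](=O)[O-])n1CCSc1nnc(-c2ccccc2Cl)o1`, is not yet measured. It is reached from compound 2 by one change on the phenyl ring: chloro in place of methyl on an aromatic carbon.

Among the measured compounds shown here, two measured steps bear on this change, since each alters the same position on that ring: the step from compound 1 to compound 2 adds a methyl there, and the step from compound 2 to compound 3 exchanges the methyl for an amino group. Neither moved the number beyond the scatter. With nothing in these data pointing to a larger effect for a chloro group, the step of a 1.0-fold higher number from compound 2 to compound 4 (0.01 log units; within the scatter) is expected to stay within the scatter as well.

On that basis compound 4 is estimated at 16000 nM in this assay, with a range from 8000 nM to 32000 nM.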

Compound 4, half-maximal inhibitory concentration: 22500 nM
Estimate against measurement, compound 4: 1.4-fold (0.15 log units) below, within the range that was stated.
By their numbers in this assay, from the lowest: compounds 2, 3, 1 and 4 (each within the scatter of the next).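

In this assay, chloro joins hydrogen, methyl and amino as a fourth group tested at this place on the phenyl ring, ortho to a large group, and it stays within the scatter of methyl (a 1.4-fold higher number from compound 2 to compound 4 (0.15 log units; within the scatter)), of amino (a 1.1-fold higher number from compound 3 to compound 4 (0.05 log units; within the scatter)) and of hydrogen (a 1.1-fold higher number from compound 1 to compound 4 (0.04 log units; within the scatter)). The change from 2-methylphenyl to 2-chlorophenyl trades one heavy atom for one heavy atom and separates nothing here, so across these four compounds the choice of group at this place makes no difference that can be read. Nothing measured alongside these numbers accounts for how alike they are.

Still open, from the compounds shown here alone, is whether a group of another kind at this place, such as a carboxylic acid, a methoxy group or a longer chain, would move the number beyond the scatter. Going by these compounds, the rest of the molecule is also the same in all four compounds, so it remains unknown whether this flat picture would hold if the nitro group on the core were replaced by a nitrile.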